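Extending a bare ring nitrogen with a piperazine-bearing chain

The compounds below may be only part of what the source reports. "The series", "measured", "known", "first", "only" and "open" are said of these compounds alone.

Compound 2 `O=C1c2c[n+]([O-])c3ccccc3c2C(=O)c2[nH]c3ccccc3c21` carries a hydrogen on the aromatic nitrogen of its shared core. Among the measured compounds shown here, in a toxicity assay on L02 cells (Homo sapiens) for cytotoxicity, read by MTT assay, with a stated time of 72 h (a lower number here means a stronger inhibitor, a higher number a weaker inhibitor), compound 2 gives 400 nM, the lowest of the three numbers measured so far, although both other compounds sit within the usual scatter of it. Compound 1 `O=C1c2c[n+]([O-])c3ccccc3c2C(=O)c2c1c1ccccc1n2Cc1cn(C[C@@H](O)CO)nn1` gives 490 nM and compound 3 `O=C1c2c[n+]([O-])c3ccccc3c2C(=O)c2c1c1ccccc1n2Cc1cn([C@@H]2C[C@H](O)[C@@H](CO)O2)nn1` gives 630 nM.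

Two measured steps exist. The step of a 1.2-fold lower number from compound 1 to compound 2 (0.09 log units; within the scatter) strips a (1-(2,3-dihydroxypropyl)-1H-1,2,3-triazol-4-yl)methyl group from the aromatic nitrogen back to hydrogen. The step of a 1.3-fold higher number from compound 1 to compound 3 (0.11 log units; within the scatter) swaps one side chain on that group for another. Neither step moves the number beyond the scatter.

Compound 4 `O=C1c2c[n+]([O-])c3ccccc3c2C(=O)c2c1c1ccccc1n2CCCCN1CCNCC1` differs from compound 2 in one place: 4-(piperazin-1-yl)butyl in place of hydrogen on an aromatic nitrogen. The step from compound 1 to compound 2 is the one that bears on this, since it also concerns what sits on that aromatic nitrogen, and it was small. A 4-(piperazin-1-yl)butyl group has not been tested here, so nothing directly shows its effect.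

Compound 4 is therefore expected to stay close to compound 2, with the step of a 1.1-fold higher number from compound 2 to compound 4 (0.05 log units; within the scatter) representing the estimated change. Compound 4 is estimated at 450 nM, with a likely range from 180 nM to 1100 nM.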

Compound 4, half-maximal inhibitory concentration: 1380 nM
Compound 4: middle estimate off by 3.1-fold (0.49 log units), on the low side, and the stated range ends below it.
By their numbers in this assay, from the lowest: compounds 2, 1 and 3 (each within the scatter of the next); then compound 4.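

Among the compounds shown here, putting 4-(piperazin-1-yl)butyl on the aromatic nitrogen of the shared core gives a 3.5-fold higher number from compound 2 to compound 4 (0.54 log units; beyond the scatter) in this assay, the first step at this position that lies beyond the scatter, so this nitrogen is not indifferent to what it carries. Having a chain there does not settle the outcome by itself: compound 1 also carries one and stays within the scatter of compound 2, while exchanging 1-(2,3-dihydroxypropyl)-1H-1,2,3-triazol-4-yl for 3-(piperazin-1-yl)propyl on the saturated chain carbon bound to that nitrogen gives a 2.8-fold higher number from compound 1 to compound 4 (0.45 log units; beyond the scatter) and shows that the identity of the chain matters. Nothing measured here explains why this chain gives a weaker number in this assay.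

The compounds shown do not separate the contribution of the piperazine ring from that of the four-carbon chain linking it to the core. A plain butyl chain without a ring, a shorter ethyl chain ending in the same piperazine, or a morpholine ring on the same butyl chain would each help to show which part of the new group goes with the change.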